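The source may report more compounds than this note shows. Statements on the series, on what has been measured and on what is new or still open speak of the compounds shown alone.

Working notes on the series. The shared core carries a benzylsulfanyl group whose aromatic ring is varied. Compound 1 `Cc1cc(S(=O)(=O)/N=C(\N)N/N=C/C#Cc2ccccc2)c(SCc2ccccc2C)cc1Cl` gives 19000 nM in a functional assay on HeLa cells (Homo sapiens) for antiproliferative activity, read by MTT assay, with a stated time of 72 h; a lower number here means a stronger inhibitor, a higher number a weaker inhibitor. Compound 2 `Cc1cc(S(=O)(=O)/N=C(\N)N/N=C/C#Cc2ccccc2)c(SCc2ccccc2C(F)(F)F)cc1Cl` gives 16000 nM in this assay. Among the measured compounds shown here, the one measured step, a 1.2-fold lower number from compound 1 to compound 2 (0.07 log units; within the scatter), puts trifluoromethyl in place of methyl on an aromatic carbon of that ring and does not separate the two compounds; compound 2 therefore stands together with compound 1, with no order between them that the numbers can support.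

Compound 3 `Cc1cc(S(=O)(=O)/N=C(\N)N/N=C/C#Cc2ccccc2)c(SCc2cccc3ccccc23)cc1Cl` is the next member. The change from compound 2 is naphthalen-1-yl in place of 2-(trifluoromethyl)phenyl on a saturated chain carbon bound to a sulfur, so the variation again falls on the ring attached to the saturated chain carbon bound to a sulfur. For the measured compounds named here, the only step that bears on it is a 1.2-fold lower number from compound 1 to compound 2 (0.07 log units; within the scatter), which shows that changing the group on this ring left this assay unmoved beyond the scatter. Going by the values given here, no measured step covers the entry of a second aromatic ring, so the expectation rests on that single step: a step of about a 1.1-fold lower number from compound 2 to compound 3 (0.03 log units; within the scatter) is expected, in no direction beyond the scatter. Compound 3 is estimated at 15000 nM in this assay, with a range from 7000 nM to 35000 nM.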

Compound 3, half-maximal inhibitory concentration: 8000 nM
For compound 3 the middle estimate is 1.9-fold (0.27 log units) above the measured one; low and high end bracket the measured number.
By their numbers in this assay, from the lowest: compounds 3, 2 and 1 (each within the scatter of the next, the first and the last beyond it).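

Among the compounds shown here, at this position, on a saturated chain carbon bound to a sulfur, naphthalen-1-yl in place of 2-methylphenyl gives the only step in this assay that clears the scatter, a 2.4-fold lower number from compound 1 to compound 3 (0.38 log units; beyond the scatter), and that step is modest. Against 2-(trifluoromethyl)phenyl, which has the same count of heavy atoms, the same group gives a 2.0-fold lower number from compound 2 to compound 3 (0.30 log units; within the scatter), so the numbers do not separate compound 3 from compound 2, and a second six-membered aromatic ring of carbon only is accommodated here without a rise in the number relative to either phenyl compound. Nothing available explains why the step from compound 1 to compound 3 clears the scatter while the step from compound 2 to compound 3 does not.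

Open, going by these compounds, is whether naphthalen-2-yl, an amine or a carboxylic acid on the aromatic ring, or a longer chain in place of the saturated chain carbon would take the number clearly beyond the level of compound 3 in this assay. Also open, on these data alone, is whether the same ring change gives a step of similar size on a different core, since all three compounds share one core.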